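Amide variation on a benzothiazole-bearing anilide, toxicity read-out

A few compounds are considered here, and "the series" means these few. Any claim that something is new, unique, unknown or untested is made for them only; others in the source may bear on it.

Compound 1: `C=C(C)C(=O)Nc1cccc(-c2nc3ccccc3s2)c1`, > 25000 nM
Compound 2: `O=C(O)/C=C/C(=O)Nc1cccc(-c2nc3ccccc3s2)c1`, > 25000 nM

In an ADME assay on BJ cells (Homo sapiens) for inhibition, with a stated time of 72 h (on this read-out lower numbers stand for an effect already at smaller amounts and higher numbers for an effect only at larger amounts of compound), compound 1 gives > 25000 nM, which is a limit of the assay and not a number. Compound 2 gives > 25000 nM in this assay, again only a limit. The step that the two limits leave unreadable from compound 1 to compound 2 therefore cannot be sized; both values sit at the limit of > 25000 nM in this assay, at which 2 of the 2 values shown sit. Compound 2 thus stands only at a limit, with no readable step leading to it.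

Compound 3, `CN(C)CCC(=O)Nc1cccc(-c2nc3ccccc3s2)c1`, differs from compound 2 by 2-(dimethylamino)ethyl in place of 2-carboxyethenyl on a carbonyl carbon. Among the compounds with values here, no measured step bears readably on this change, so compound 3 is expected to show no step beyond the scatter, a step that the limit leaves unreadable from compound 2 to compound 3. Compound 3 is estimated at 30000 nM, within 10000 nM to 100000 nM, most likely reported again as a limit.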

Compound 3, half-maximal effective concentration: > 25000 nM
Compound 3 ended at the assay's limit; the forecaster's own chance of this, stated with the estimate: 70%; the middle value lies beyond the limit too.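

In this assay compound 3 gives > 25000 nM, again a limit and not a number, so no step linking compound 1, compound 2 and compound 3 can be read: the limit of > 25000 nM in this assay, at which 3 of the 3 values shown sit.

The compounds shown leave open which group on the carbonyl carbon, if any, would give a readable value in this assay.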